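The source may report more compounds than this note shows. Statements on the series, on what has been measured and on what is new or still open speak of the compounds shown alone.

Measured compounds in a functional assay on MDA-MB-435S cells (Homo sapiens) for cytotoxicity, read by MTT assay, with a stated time of 72 h; a lower number here means a stronger inhibitor, a higher number a weaker inhibitor:
- compound 1 `O=c1cc(CSc2nc3ccccc3s2)oc2ccccc12` gives > 25000 nM, a limit of the assay
- compound 2 `Cc1nnc(SCc2cc(=O)c3ccccc3o2)s1` gives > 25000 nM, a limit of the assay
- compound 3 `Cc1ccc2oc(CSc3nc4ccccc4s3)cc(=O)c2c1` gives > 25000 nM, a limit of the assay

Compound 3 differs from compound 1 by methyl in place of hydrogen on an aromatic carbon. The step that the two limits leave unreadable from compound 1 to compound 3 cannot be read, because of the limit of > 25000 nM in this assay, at which 3 of the 3 values shown sit. How the core of compound 2 differs from that of compound 1 is not broken down here.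

Compound 4 `Cc1ccc2oc(CSc3nnc(C)s3)cc(=O)c2c1` differs from compound 2 by methyl in place of hydrogen on an aromatic carbon, the same change as from compound 1 to compound 3. Since compound 2 itself sits at a limit in this assay, the step that the limit leaves unreadable from compound 2 to compound 4 is expected to be no more readable than the measured one. Compound 4 is therefore expected to give 30000 nM in this assay, within 12000 nM to 100000 nM, most probably again reported only as a limit.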

Compound 4, half-maximal inhibitory concentration: > 25000 nM
Compound 4: only a limit was reported; the forecaster's own chance of this, stated with the estimate: 85%; the middle value does not contradict the limit.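

The step from compound 2 to compound 4 cannot be read, and neither can any other new step, as both compounds give only a limit: the limit of > 25000 nM in this assay, at which 4 of the 4 values shown sit.

Going by these compounds, whether methyl in place of hydrogen on the aromatic carbon changes potency, and how the four compounds rank, stays open.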